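Moving the Pyridine Nitrogen Around the Pendant Ring

A few compounds are considered here, and "the series" means these few. Any claim that something is new, unique, unknown or untested is made for them only; others in the source may bear on it.

For the measured compounds named here, in an ADME assay on LLC-PK1 cells (Sus scrofa) for permeability (on this read-out lower numbers stand for lower permeability and higher numbers for higher permeability), compound 2 `Cn1cc(C(=O)Nc2ccc(-c3ccncc3)c(C(F)(F)F)c2)c(=O)c2ccccc21` gives 15 10^-6 cm/s, the highest of the three numbers so far recorded. Its nearest neighbour is compound 1 `Cn1cc(C(=O)Nc2ccc(-c3ccccn3)c(C(F)(F)F)c2)c(=O)c2ccccc21`, which in this assay gives 11 10^-6 cm/s. Furthest from it is compound 3 `Cn1cc(C(=O)Nc2ccc(-c3ccccc3)c(C(F)(F)F)c2)c(=O)c2cccnc21`, which gives 2.2 10^-6 cm/s in this assay; compound 3 differs from compound 2 in more than one place, so no single step between them is recorded, and the two values simply show that compound 3 lies beyond the scatter below compound 2.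

Compound 4 `Cn1cc(C(=O)Nc2ccc(-c3cccnc3)c(C(F)(F)F)c2)c(=O)c2ccccc21` is the next compound in line. It differs from compound 2 in one place: pyridin-3-yl in place of pyridin-4-yl on an aromatic carbon. Going by the values given here, the only measured step that bears on this change is the one that also exchanged one pyridinyl for another, which gave a 1.4-fold higher number from compound 1 to compound 2 (0.13 log units; within the scatter), a difference inside the scatter. On that basis the move to pyridin-3-yl is expected to produce no step beyond the scatter in this assay, so that the number for compound 4 is expected to stay close to that of compound 2, the expected step being a 1.2-fold lower number from compound 2 to compound 4 (0.06 log units; within the scatter). Compound 4 is therefore estimated at 13 10^-6 cm/s, with a range from 7 10^-6 cm/s to 25 10^-6 cm/s.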

Compound 4, apparent permeability in the LLC-PK1 assay: 18 10^-6 cm/s
Beside the measured number, compound 4's estimate is 1.4-fold (0.14 log units) below it; low and high end bracket the measured number.
By their numbers in the LLC-PK1 assay, from the lowest: compound 3; then compounds 1, 2 and 4 (each within the scatter of the next).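

With compound 4 in hand, all three pyridinyl groups have been compared at this aromatic carbon, ortho to the trifluoromethyl group, and in the LLC-PK1 assay none of the exchanges moves the number beyond the scatter: the measured steps are a 1.2-fold higher number from compound 2 to compound 4 (0.08 log units; within the scatter) and a 1.6-fold higher number from compound 1 to compound 4 (0.21 log units; within the scatter). The same exchange of pyridin-4-yl for pyridin-3-yl does separate the pair in another read-out, for in a physicochemical assay for solubility, in phosphate buffer, at pH 7.4 (on this read-out higher numbers stand for higher solubility and lower numbers for lower solubility), compound 2 gives 7.9 ug/mL, and the step is an at least 7.9-fold lower number from compound 2 to compound 4 (0.89 log units; beyond the scatter), so a change that leaves no readable trace on permeability is not silent on solubility. In the physicochemical assay compound 4 gives < 1 ug/mL, which is a limit of the assay and not a number: the limit of < 1 ug/mL in the physicochemical assay, at which 1 of the 2 values shown sits.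

The compounds shown do not say what lies behind this split between the two read-outs, nor how far the solubility of compound 4 extends past the limit. They also leave open how both read-outs would respond if this aromatic carbon carried a group of another kind, such as an amine or a carboxylic acid, in place of a pyridinyl group.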